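Adding a Chloropentynyl Arm to a Compound Beyond Measurement

The source may report more compounds than this note shows. Statements on the series, on what has been measured and on what is new or still open speak of the compounds shown alone.

compound 1 `O=c1nc2oc(CCCCl)c(C#CCCCCl)c2cn1Cc1cn(Cc2ccccc2)nn1`: 32800 nM
compound 2 `O=c1nc2oc(CCCCl)cc2cn1Cc1cn(-c2ccc(Cl)cc2)nn1`: > 100000 nM

In a functional assay on CFPAC-1 cells (Homo sapiens) for antiproliferative activity, read by MTT assay, with a stated time of 72 h (on this read-out higher numbers stand for weaker inhibition and lower numbers for stronger inhibition), compound 1 gives 32800 nM. For compound 2 the assay reports only a limit, > 100000 nM, not a number. From the compounds shown here alone, compound 2 thus stands at the limit of > 100000 nM in this assay, at which 1 of the 2 values shown sits, and its true value is unknown.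

Compound 3 `O=c1nc2oc(CCCCl)c(C#CCCCCl)c2cn1Cc1cn(-c2ccc(Cl)cc2)nn1` carries 5-chloropent-1-yn-1-yl in place of hydrogen on an aromatic carbon. Within the data shown here, no step between measured compounds matches this change; compound 1 also bears that alkyne arm but differs in a second place too, so its value only hints. A move toward stronger inhibition, an at least 1.6-fold lower number from compound 2 to compound 3 (0.22 log units; that floor lies within the scatter), is expected, possibly still inside the scatter. Compound 3 is estimated at 60000 nM, between 20000 nM and 200000 nM.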

Compound 3, half-maximal inhibitory concentration: > 100000 nM
Compound 3 was reported as a limit; the forecaster's own chance of this, stated with the estimate: 45%; at least 1.6-fold (0.22 log units) between middle value and limit.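

In this assay, among these compounds, the first comparison that differs in one place holds the 5-chloropent-1-yn-1-yl arm fixed: 4-chlorophenyl in place of benzyl on an aromatic nitrogen gives an at least 3.0-fold higher number from compound 1 to compound 3 (0.48 log units; beyond the scatter). So with this arm present, the benzyl compound is the only one with a measured number. The result for compound 3 is a limit, and the step that adds the arm cannot be read, with both of its ends reported only as limits: the limit of > 100000 nM in this assay, at which 2 of the 3 values shown sit.

From the compounds shown here alone, whether the arm changes activity at this aromatic carbon therefore stays open. Also open, going by these compounds, is how an amine or a carboxylic acid in place of the chlorine at the end of the chain would read in this assay.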